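Cyclobutylcarbonyl to acetyl on the amide of compound 1

This account rests on a few compounds, and the source may have more. Where it says the series, first, only, none or still open, it means among the compounds named here.

Measured so far:
compound 1 `O=C(Nc1cc(Oc2ccc(Nc3nccc4[nH]cc(-c5ccc(F)cc5)c(=O)c34)cc2F)ccn1)C1CCC1`: 46%
compound 2 `CCn1cc(-c2ccc(F)cc2)c(=O)c2c(Nc3ccc(Oc4ccnc(NC(=O)C5CC5)c4)c(F)c3)nccc21`: 15.8%

In a functional assay on HT-29 cells (Homo sapiens) for antiproliferative activity, read by MTT assay, with a stated time of 72 h, tested at 10 uM (on this read-out lower numbers stand for less inhibition and higher numbers for more inhibition at the one concentration tested (going by the name of the read-out)), compound 1 gives 46%, the higher of the two numbers in hand. Within the data shown here, compound 2 gives 15.8%, which is lower by a gap beyond the usual scatter; the two compounds differ in more than one place, so no single step is read from them.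

Compound 3 `CC(=O)Nc1cc(Oc2ccc(Nc3nccc4[nH]cc(-c5ccc(F)cc5)c(=O)c34)cc2F)ccn1` has not been measured. It differs from compound 1 in one place only: methyl in place of cyclobutyl on a carbonyl carbon. Among the measured compounds shown here, no measured pair shows this change, so its effect is unknown from the data. With only the value of compound 1 to go by, compound 3 is expected to sit near it, with a modest downward drift of a number 8 percentage points lower from compound 1 to compound 3 (within the scatter) as the working estimate. For compound 3 the expected value in this assay is 38%, with a range from 15% to 60%.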

Compound 3, a percentage reported as inhibition, at one concentration (the size of the read-out at that concentration, not a potency): 36.8%
For compound 3 the middle estimate is 1.2 percentage points above the measured one; the range from low to high includes it.
By their numbers in this assay, from the lowest: compound 2; then compounds 3 and 1 (each within the scatter of the next).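

In this assay, among these compounds, the exchange of cyclobutyl for methyl on a carbonyl carbon reads as a number 9.2 percentage points lower from compound 1 to compound 3 (within the scatter) and is the first single-place step at this position. For this pair, then, the ring of four carbons is not needed to hold the read-out at this level, since the acetamido compound stays within the scatter of the (cyclobutylcarbonyl)amino compound at the one concentration tested. No measured data on these two groups bear on this step.

Open, as far as these compounds go, is what a longer chain, an amine or a carboxylic acid on this carbonyl carbon would give in this assay. From the compounds shown here alone, compound 2 differs from both compound 1 and compound 3 in more than one place, so what separates it from them also stays open.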